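The source may hold more compounds than are shown below. What is called first, only, known or untested is meant among the compounds shown, and "the series" means these compounds.

In a functional assay on SGC-7901 cells (Homo sapiens) for inhibition, read by MTT assay, with a stated time of 24 h (a higher number here means a weaker inhibitor, a lower number a stronger inhibitor), compound 1 `CC1(C)[C@H]2CC[C@]1(C)N(Cc1cn(-c3ccc(C#N)cc3)nn1)C(=O)C2` gives 500 nM and compound 2 `CC1(C)[C@H]2CC[C@]1(C)N(Cc1cn(-c3ccccc3C#N)nn1)C(=O)C2` gives 260 nM so the two numbers stand within the scatter of each other. Going by the values given here, compound 3 `CC1(C)[C@H]2CC[C@]1(C)N(Cc1cn(-c3ccccc3F)nn1)C(=O)C2` is still unmeasured and carries fluoro in place of cyano on an aromatic carbon ortho to a large group fluoro in place of cyano on an aromatic carbon as its one difference from compound 2. Among the compounds with values here, the only measured step of a 1.9-fold lower number from compound 1 to compound 2 (0.28 log units; within the scatter) lies within the scatter and concerns where the cyano sits, not its replacement, so it offers weak guidance. The estimated 1.3-fold higher number from compound 2 to compound 3 (0.13 log units; within the scatter) is expected to stay within the scatter in this assay with no firm direction. Compound 3 is expected near 350 nM within an estimated range of 120 nM to 1000 nM for this measurement.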

Compound 3, half-maximal inhibitory concentration: 300 nM
Compound 3: the middle estimate sits 1.2-fold (0.07 log units) above what was measured; the range from low to high includes it.
By their numbers in this assay, from the lowest: compounds 2, 3 and 1 (each within the scatter of the next).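

In this assay the position ortho to a large group takes fluoro in place of cyano with a 1.2-fold higher number from compound 2 to compound 3 (0.06 log units; within the scatter), so the nitrile is not needed there for a value in this range, which compound 1 and compound 2 could not show. The change to 2-fluorophenyl from 4-cyanophenyl gives a 1.7-fold lower number from compound 1 to compound 3 (0.22 log units; within the scatter) and likewise separates nothing. No measured evidence bears on these results. Still open, from the compounds shown here alone, is whether an amine or a carboxylic acid at this position would shift the number beyond the scatter.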